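This account rests on a few compounds, and the source may have more. Where it says the series, first, only, none or still open, it means among the compounds named here.

Measured so far in a functional assay on ileum (Cavia porcellus) for antagonist activity, with a stated time of 30 s; a higher number here means a weaker inhibitor, a lower number a stronger inhibitor
Compound 1 `O=C(O)c1cc(=O)c2cc(CCCc3ccccc3)ccc2o1` gives 3 ug/mL
Compound 2 `C=CCc1c(OCC(O)COc2ccc3c(=O)cc(C(=O)O)oc3c2)ccc(C(C)=O)c1O` gives 0.1 ug/mL

Compound 2 holds the lower of the two numbers, and its gap to compound 1 lies beyond the scatter. Compound 3 `C=CCc1c(OCC(O)COc2ccc3c(=O)cc(C(=O)O)oc3c2CC=C)ccc(C(C)=O)c1O` carries allyl in place of hydrogen on an aromatic carbon on the core of compound 2, allyl in place of hydrogen on an aromatic carbon. Going by the values given here, no measured pair shows this change, so the expectation is only a judgement: a moderate step to a lower number in this assay and so a stronger inhibitor, perhaps only just beyond the scatter. The estimate means an expected 3.3-fold lower number from compound 2 to compound 3 (0.52 log units; beyond the scatter) in this read-out. Compound 3 is estimated at 0.03 ug/mL in this assay with an expected range from 0.008 ug/mL to 0.12 ug/mL overall.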

Compound 3, half-maximal inhibitory concentration: 0.05 ug/mL
For compound 3 the middle estimate is 1.7-fold (0.22 log units) below the measured one; measured number inside the range.
By their numbers in this assay, from the lowest: compounds 3 and 2 (each within the scatter of the next); then compound 1.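

In this assay, allyl in place of hydrogen on this aromatic carbon, ortho to a fused ring and ortho to a large group, gives a 2.0-fold lower number from compound 2 to compound 3 (0.30 log units; within the scatter). Going by these compounds alone, the position therefore takes the added allyl with no change that can be told from the scatter, something the earlier compounds could not show. Nothing available here accounts for this result. The compounds shown leave open whether a methyl, a longer chain such as propyl, or an amine on this same carbon would be tolerated equally well.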